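Phenyl in place of propyl on the amide nitrogen

A few compounds are considered here, and "the series" means these few. Any claim that something is new, unique, unknown or untested is made for them only; others in the source may bear on it.

Compound 2 `CCCN(Cc1cccs1)C(=O)COc1ccc(C)cc1` carries a propyl group on its amide-type nitrogen, and in an assay on HEK293 cells for agonist activity at transient receptor potential cation channel subfamily M member 8 (Homo sapiens), read by fluorescence and calcium flux, with a stated time of 15 min (on this read-out higher numbers stand for an effect only at larger amounts of compound and lower numbers for an effect already at smaller amounts), compound 2 gives 40 nM, the lowest of the two numbers recorded, while its nearest neighbour, compound 1 `Cc1ccc(OCC(=O)N(Cc2cccs2)C(C)C)cc1`, gives 70 nM. Within the data shown here, the only measured step, a 1.8-fold lower number from compound 1 to compound 2 (0.24 log units; within the scatter), comes from exchanging isopropyl for propyl and lies within the scatter. Compound 3 `Cc1ccc(OCC(=O)N(Cc2cccs2)c2ccccc2)cc1` has not yet been measured; it differs from compound 2 by phenyl in place of propyl on an amide-type nitrogen. Among the measured compounds shown here, no measured pair tests an aromatic group in that place, so the one known step offers little guidance beyond showing that a small change at this nitrogen did not move the number much. Compound 3 is therefore estimated to give 120 nM, within 30 nM to 500 nM, the expected step of a 3.0-fold higher number from compound 2 to compound 3 (0.48 log units; beyond the scatter) being uncertain in direction.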

Compound 3, half-maximal effective concentration: 23 nM
Estimate against measurement, compound 3: 5.2-fold (0.72 log units) above; the measured number lies below the stated range.
By their numbers in this assay, from the lowest: compounds 3, 2 and 1 (each within the scatter of the next, the first and the last beyond it).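

In this assay the amide-type nitrogen accepts a six-membered aromatic ring as well as a saturated chain: phenyl in place of propyl gives a 1.7-fold lower number from compound 2 to compound 3 (0.24 log units; within the scatter) and so cannot be told apart from repeat measurement. Phenyl in place of isopropyl gives a 3.0-fold lower number from compound 1 to compound 3 (0.48 log units; beyond the scatter) and is the only step so far to clear the scatter, although the two chains themselves remain within the scatter of each other. No supporting data explain how phenyl is accepted at this nitrogen.

The compounds shown leave open how a longer chain such as butyl, or a benzyl group, would read at this place. They also do not show what a pyridine ring, or a phenyl ring carrying a methoxy group or a carboxylic acid, would give there.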